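The compounds below may be only part of what the source reports. "The series", "measured", "known", "first", "only" and "open" are said of these compounds alone.

Working notes on the selenocyanate carbamate series. In a functional assay on CCRF-CEM cells (Homo sapiens) for cytotoxicity, read by MTT assay, with a stated time of 72 h (on this read-out lower numbers stand for stronger inhibition of growth and higher numbers for weaker inhibition of growth), compound 2 `C=CCOC(=O)Nc1ccc([Se]C#N)cc1` gives 38100 nM, and in this assay compound 1 `CCCOC(=O)Nc1ccc([Se]C#N)cc1` gives 38400 nM; the two sit within the scatter of each other, as the step of a 1.0-fold lower number from compound 1 to compound 2 (0.00 log units; within the scatter) shows. Compound 3 `CCOC(=O)Nc1ccc([Se]C#N)cc1` differs from compound 2 by methyl in place of vinyl on a saturated chain carbon bound to an oxygen next to a carbonyl group. Among the measured compounds shown here, the only step that bears on this position, from compound 1 to compound 2, was flat, so for compound 3 no step beyond the scatter is expected, a 1.0-fold lower number from compound 2 to compound 3 (0.00 log units; within the scatter). Compound 3 is therefore estimated at 38000 nM, with a range of 19000 nM to 76000 nM.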

Compound 3, concentration for total growth inhibition: 39100 nM
Beside the measured number, compound 3's estimate is 1.0-fold (0.01 log units) below it; the measured number falls inside the stated range.
By their numbers in this assay, from the lowest: compounds 2, 1 and 3 (each within the scatter of the next).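

In this assay, methyl in place of vinyl on a saturated chain carbon bound to an oxygen next to a carbonyl group gives a 1.0-fold higher number from compound 2 to compound 3 (0.01 log units; within the scatter), so removing the double bond outside aromatic rings has no effect beyond the scatter. Hydrogen in place of methyl, two bonds along the chain from that oxygen, gives a 1.0-fold higher number from compound 1 to compound 3 (0.01 log units; within the scatter), so ethyl now also matches the earlier pair. Nothing available explains this flatness.

Still open, from the compounds shown here alone, is whether a longer chain, a phenyl ring or a terminal amine at this position would move the number beyond the scatter.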